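The source may report more compounds than this note shows. Statements on the series, on what has been measured and on what is new or still open speak of the compounds shown alone.

In a functional assay on L1210 cells (Mus musculus) for antiproliferative activity, with a stated time of 48 h (on this read-out lower numbers stand for stronger inhibition and higher numbers for weaker inhibition), three compounds have been measured:

- Compound 1 `C=C(Br)C(=O)Nc1ccc(C(=O)/C=C/c2ccccc2)cc1`: 880 nM
- Compound 2 `C=C(Br)C(=O)Nc1ccc(C(=O)/C=C/c2ccccc2OC)cc1`: 1700 nM
- Compound 3 `C=C(Br)C(=O)Nc1ccc(C(=O)/C=C/c2cccc(OC)c2OC)cc1`: 1100 nM

Compound 2, at 1700 nM, stands level with the other two, within the scatter of each. Compound 4 `COc1ccccc1/C=C/C(=O)c1ccc(N)cc1` differs from compound 2 as follows: hydrogen in place of (1-bromoethenyl)carbonyl on a nitrogen on an aromatic ring. The two measured steps, a 1.9-fold higher number from compound 1 to compound 2 (0.29 log units; within the scatter) and a 1.5-fold lower number from compound 2 to compound 3 (0.19 log units; within the scatter), each put methoxy in place of hydrogen on an aromatic carbon and stay within the scatter. Neither touches the nitrogen, so they bear only weakly on this change. Within the data shown here, all three measured compounds carry the (1-bromoethenyl)carbonyl group, and the data hold no measured compound without it. The expectation in this assay is nevertheless a clear step to a higher number, meaning weaker inhibition, a judgement that rests on the size of the change alone and starts from compound 2 at 1700 nM. The expected step is an 8.8-fold higher number from compound 2 to compound 4 (0.95 log units; beyond the scatter), and its size is poorly fixed. For compound 4 the estimated value is 15000 nM, with an expected range of 3000 nM to 60000 nM.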

Compound 4, half-maximal inhibitory concentration: 12000 nM
Beside the measured number, compound 4's estimate is 1.3-fold (0.10 log units) above it; measured number inside the range.
By their numbers in this assay, from the lowest: compounds 1, 3 and 2 (each within the scatter of the next); then compound 4.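

In this assay, hydrogen in place of (1-bromoethenyl)carbonyl on the nitrogen gives a 7.1-fold higher number from compound 2 to compound 4 (0.85 log units; beyond the scatter), the only step shown that lies beyond the scatter, and the earlier methoxy steps did not separate any compounds in this way. It shows that, on the background of compound 2, the group on this nitrogen matters more to the read-out than either methoxy change, although inhibition does not vanish when the group leaves. Nothing measured here accounts for the size of this step.

The compounds shown leave open which part of the group carries the step; an acetyl or a plain propenoyl group on the same nitrogen would separate the bromine from the carbonyl. From the compounds shown here alone, it also remains open whether the step would be the same size on the cores of compound 1 and compound 3.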